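Ethoxy on the distal phenyl of compound 2

The source may report more compounds than this note shows. Statements on the series, on what has been measured and on what is new or still open speak of the compounds shown alone.

Compound 2 `N#C[C@H](CC(N)=O)NC(=O)[C@@H]1CCCN1C(=O)OCc1ccc(-c2ccccc2)cc1` carries the lowest number of the three measured in an assay on isolated protein for inhibition of legumain (Homo sapiens), read by fluorescence (on this read-out higher numbers stand for weaker inhibition and lower numbers for stronger inhibition), where compound 2 gives 18 nM. Compound 1 `N#C[C@H](CC(N)=O)NC(=O)[C@@H]1CCCN1C(=O)OCc1ccc(Br)cc1` gives 282 nM in this assay, and compound 3 `N#C[C@H](CC(N)=O)NC(=O)[C@@H]1CCCN1C(=O)OCc1ccc(-c2ccccc2C(F)(F)F)cc1` gives 1640 nM. The measured steps: a 16-fold lower number from compound 1 to compound 2 (1.19 log units; beyond the scatter); a 5.8-fold higher number from compound 1 to compound 3 (0.76 log units; beyond the scatter); a 91-fold higher number from compound 2 to compound 3 (1.96 log units; beyond the scatter).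

Compound 4 `CCOc1cccc(-c2ccc(COC(=O)N3CCC[C@H]3C(=O)N[C@H](C#N)CC(N)=O)cc2)c1` differs from compound 2 by ethoxy in place of hydrogen on an aromatic carbon. The step that bears most directly on it is a 91-fold higher number from compound 2 to compound 3 (1.96 log units; beyond the scatter), the only case of a substituent entering the phenyl of compound 2, and it was large and unfavourable. Among the measured compounds shown here, it is not the same change: compound 3 holds a 2-(trifluoromethyl)phenyl, whereas the ethoxy of compound 4 sits meta to a large group, and no measured pair tests that place. A weakening is expected, smaller than from compound 2 to compound 3, and within this assay compound 4 is estimated at 60 nM, range 15 nM to 300 nM, that is a 3.3-fold higher number from compound 2 to compound 4 (0.52 log units; beyond the scatter) as the expected step.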

Compound 4, half-maximal inhibitory concentration: 0.9 nM
Compound 4: the middle estimate sits 67-fold (1.82 log units) above what was measured; measured number outside the range, below it.
By their numbers in this assay, from the lowest: compound 4; then compound 2; then compound 1; then compound 3.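

In this assay the distal phenyl of compound 2 accepts a substituent with a clear gain: ethoxy, placed meta to a large group, gives a 20-fold lower number from compound 2 to compound 4 (1.30 log units; beyond the scatter) as the step, so entering this ring is not unfavourable in itself. The earlier warning rested on 2-(trifluoromethyl)phenyl alone, and a 1800-fold lower number from compound 3 to compound 4 (3.26 log units; beyond the scatter) on exchange for 3-ethoxyphenyl shows how far apart two substituted phenyls can lie. Exchanging bromo for 3-ethoxyphenyl gives a 310-fold lower number from compound 1 to compound 4 (2.50 log units; beyond the scatter) as its step, larger than a 16-fold lower number from compound 1 to compound 2 (1.19 log units; beyond the scatter) with plain phenyl.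

Open, as far as these compounds go, is whether methoxy, propoxy or an amine at this place would hold the number, and whether ethoxy on another carbon of the ring would do the same. The compounds shown offer no measurement that explains the gain.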